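The compounds below may be only part of what the source reports. "The series", "measured", "known", "first", "only" and "open" are said of these compounds alone.

Compound 3 `C(#Cc1nc2c(s1)CN(C1CCCCC1)CC2)c1ccccc1` stands at the edge of what an assay on HEK293 cells for negative allosteric modulation of metabotropic glutamate receptor 5 (Homo sapiens), read by FLIPR, with a stated time of 1 h (a lower number here means a stronger inhibitor, a higher number a weaker inhibitor), can report: in this assay compound 3 gives > 10000 nM, which is a limit rather than a number. Compound 1 `CN1CCc2nc(C#Cc3ccccc3)sc2C1` likewise reaches only a limit, giving > 10000 nM in this assay. Compound 2 `CC(C)CN1CCc2nc(C#Cc3ccccc3)sc2C1` gives 650 nM in this assay. The measured steps are an at least 15-fold lower number from compound 1 to compound 2 (1.18 log units; beyond the scatter), an at least 15-fold higher number from compound 2 to compound 3 (1.18 log units; beyond the scatter) and a step that the two limits leave unreadable from compound 1 to compound 3, the last left unreadable by the limit of > 10000 nM in this assay, at which 2 of the 3 values shown sit. Compound 4 `CC1CC1C(=O)N1CCc2nc(C#Cc3ccccc3)sc2C1` arises through ((2-methylcyclopropyl)carbonyl in place of cyclohexyl on an amine nitrogen in a ring). Within the data shown here, no measured step replaces the amine substituent with a carbonyl-bearing group, so the direction stays open; the readable steps only show that a change on this nitrogen can shift the number strongly either way. Compound 4 is expected at 3000 nM, between 300 nM and 20000 nM, which means an at least 3.3-fold lower number from compound 3 to compound 4 (0.52 log units; beyond the scatter) is expected.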

Compound 4, half-maximal inhibitory concentration: > 10000 nM
Compound 4: no number, only a limit; the forecaster's own chance of this, stated with the estimate: 40%; middle value at least 3.3-fold (0.52 log units) away from the limit.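

Compound 4 reaches only a limit, so a carbonyl-bearing group on this amine nitrogen joins methyl and cyclohexyl there. Putting (2-methylcyclopropyl)carbonyl in place of isobutyl gives an at least 15-fold higher number from compound 2 to compound 4 (1.18 log units; beyond the scatter), which leaves isobutyl as the only one of the four substituents with a number. The steps from compound 1 and compound 3 to compound 4 cannot be read, because both ends of each sit at a limit: the limit of > 10000 nM in this assay, at which 3 of the 4 values shown sit.

Going by these compounds, how compound 1, compound 3 and compound 4 rank therefore stays open. So does whether a benzyl group or a smaller acyl such as acetyl on this nitrogen would give a number.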